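The compounds below may be only part of what the source reports. "The series", "measured", "known", "first", "only" and "open" are said of these compounds alone.

Compound 1, whose structure is `Cc1ccc2[nH]c(=O)c(-c3nc4cc([N+](=O)[O-])ccc4[nH]3)cc2c1`, was tested in a functional assay on HepG2 cells (Homo sapiens) for cytotoxicity, read by MTT assay, with a stated time of 48 h; on this read-out lower numbers stand for stronger inhibition and higher numbers for weaker inhibition. In this assay compound 1 reaches only a limit, > 100000 nM, so no number is known for it. Compound 2, with the structure `O=c1[nH]c2ccccc2cc1-c1nc2cc([N+](=O)[O-])ccc2[nH]1`, is also known only as a limit in this assay, > 100000 nM. For the measured compounds named here, the one measured step, a step that the two limits leave unreadable from compound 1 to compound 2, is therefore unreadable in size, and the only firm point is the limit of > 100000 nM in this assay, at which 2 of the 2 values shown sit.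

The compound to be judged is compound 3, with the structure `Cc1ccc2[nH]c(=O)c(-c3nc4cc(Cl)ccc4[nH]3)cc2c1`. It differs from compound 1 by chloro in place of nitro on an aromatic carbon. Going by the values given here, no measured step touches the exchange of a nitro group for a chloro group, and the step that is measured cannot be read. The expectation for compound 3 in this assay rests only on compound 1 sitting at the limit > 100000 nM, so compound 3 is estimated to give 100000 nM, within 30000 nM to 300000 nM. The expected step of a number no higher from compound 1 to compound 3 (the limit leaves the size open) is thus no change beyond the scatter.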

Compound 3, half-maximal inhibitory concentration: 26600 nM
Estimate against measurement, compound 3: 3.8-fold (0.58 log units) above, and the stated range ends above it.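

In this assay, for the compounds shown here, chloro in place of nitro on this aromatic carbon gives the first step that can be read, an at least 3.7-fold lower number from compound 1 to compound 3 (0.57 log units; beyond the scatter). This shows that the group at this position can move the read-out, and with chloro there the result becomes an actual number, with compound 3 at 26600 nM. Compound 1 and compound 2 each stay at a limit, so the step between them, hydrogen in place of methyl, cannot be read, and compound 3 alone gives a measured number: the limit of > 100000 nM in this assay, at which 2 of the 3 values shown sit.

Going by these compounds alone, with only one exchange at this position on view, it stays open whether the lower number is particular to chloro or whether another group there, such as an amine, a methoxy group or a carboxylic acid, would give a similar or a different result. It also stays open what the methyl group contributes once chloro is in place, as the compounds shown include no partner of compound 3 that carries hydrogen in place of that methyl.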